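Allyl for 4-chlorobenzyl at the sulfur of compound 1

A few compounds are considered here, and "the series" means these few. Any claim that something is new, unique, unknown or untested is made for them only; others in the source may bear on it.

Compound 1 `Cc1cc(Nc2cc(-c3ccccc3)[nH]n2)n2nc(SCc3ccc(Cl)cc3)nc2n1` gives 3950 nM in a functional assay on MGC-803 cells (Homo sapiens) for inhibition, read by MTT assay, with a stated time of 72 h; a lower number here means a stronger inhibitor, a higher number a weaker inhibitor. Among the three measured compounds it holds the second highest number; compound 3 `Cc1cc(Nc2cc(-c3ccc(Cl)cc3)[nH]n2)n2nc(SCc3ccc(Br)cc3)nc2n1` gives 2780 nM and compound 2 `CCCCCc1c(C)nc2nc(SCc3ccc(Cl)cc3)nn2c1Nc1cc(-c2ccccc2)[nH]n1` gives 7140 nM, both within the scatter of compound 1. Among the compounds with values here, the one measured step in this set, pentyl in place of hydrogen on an aromatic carbon, gave a 1.8-fold higher number from compound 1 to compound 2 (0.26 log units; within the scatter). Compound 4 `C=CCSc1nc2nc(C)cc(Nc3cc(-c4ccccc4)[nH]n3)n2n1` differs from compound 1 by vinyl in place of 4-chlorophenyl on a saturated chain carbon bound to a sulfur. Within the data shown here, no measured step touches the group on the sulfur, so nothing here predicts the outcome, and a shift beyond the scatter is only weakly expected. Compound 4 is therefore estimated at 8000 nM, with a range from 2500 nM to 25000 nM, a step of a 2.0-fold higher number from compound 1 to compound 4 (0.31 log units; beyond the scatter) expected.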

Compound 4, half-maximal inhibitory concentration: 17200 nM
The estimate for compound 4 lay 2.2-fold (0.33 log units) below the measured number, and the stated range covers the measured number.
By their numbers in this assay, from the lowest: compounds 3, 1 and 2 (each within the scatter of the next, the first and the last beyond it); then compound 4.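

In this assay, within the data shown here, the change from 4-chlorobenzyl to allyl on the sulfur gave a 4.4-fold higher number from compound 1 to compound 4 (0.64 log units; beyond the scatter) and so is the first step here to pass beyond the scatter. The group on the sulfur is thus a place where the number can move, and here the smaller allyl goes with the weaker result. Nothing measured here explains this shift.

The chlorine and the aromatic ring leave together in this change, so their shares remain unseparated. Plain benzyl, or a longer chain such as hexyl, on the sulfur would leave open questions to test.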